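Working notes on the step from compound 3 to compound 4

This account rests on a few compounds, and the source may have more. Where it says the series, first, only, none or still open, it means among the compounds named here.

Values so far in an ADME assay on J774 cells (Mus musculus, strain BALB/c) for cytotoxicity, read by resazurin assay, with a stated time of 72 h; a higher number here means that more compound is tolerated, a lower number that less compound is tolerated:
Compound 1 `CC(/C=N/Nc1ccc([N+](=O)[O-])cc1)=N\NC(=O)c1ccc(N)cc1`: 75000 nM
Compound 2 `CC(/C=N/Nc1ccc([N+](=O)[O-])cc1)=N\NC(=O)c1ccccc1C`: > 100000 nM, a limit of the assay
Compound 3 `CC(/C=N/Nc1ccc([N+](=O)[O-])cc1)=N\NC(=O)c1ccc(Cl)cc1`: 63900 nM

Compound 3 holds the lowest of the two numbers; its nearest neighbour is compound 1, the step being a 1.2-fold lower number from compound 1 to compound 3 (0.07 log units; within the scatter). The step of an at least 1.5-fold lower number from compound 2 to compound 3 (0.19 log units; that floor lies within the scatter) rests on the limit (the limit of > 100000 nM in this assay, at which 1 of the 3 values shown sits). The unmeasured compound 4 `CC(/C=N/Nc1ccc([N+](=O)[O-])cc1)=N\NC(=O)c1ccc(N(C)C)cc1` differs from compound 3 by dimethylamino in place of chloro on an aromatic carbon. Within the data shown here, the only step touching the same position, a 1.2-fold lower number from compound 1 to compound 3 (0.07 log units; within the scatter), lay within the scatter, so for compound 4 no change beyond the scatter is expected in this assay, a 1.1-fold higher number from compound 3 to compound 4 (0.04 log units; within the scatter). Compound 4 is therefore estimated at 70000 nM, with a range from 35000 nM to 140000 nM.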

Compound 4, half-maximal cytotoxic concentration: > 100000 nM
Compound 4 gave a limit, no number; the forecaster's own chance of this, stated with the estimate: 20%; middle value at least 1.4-fold (0.15 log units) from the limit.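

In this assay compound 4 gives a limit, not a number, the first at this aromatic carbon, where amino and chloro both gave numbers. The readable steps, an at least 1.5-fold higher number from compound 3 to compound 4 (0.19 log units; that floor lies within the scatter) and an at least 1.3-fold higher number from compound 1 to compound 4 (0.12 log units; that floor lies within the scatter), show no change beyond the scatter, yet neither sets an upper bound on the change. With compound 2 the step cannot be read, both values being limits: the limit of > 100000 nM in this assay, at which 2 of the 4 values shown sit.

From the compounds shown here alone, whether a carboxylic acid, a methoxy group or a longer alkylamino chain on this aromatic carbon would move the number beyond the scatter stays open.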